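The source may hold more compounds than are shown below. What is called first, only, known or untested is meant among the compounds shown, and "the series" means these compounds.

In a functional assay on CHO cells for antagonist activity at adenosine receptor A2b (Homo sapiens), read by cAMP accumulation, with a stated time of 10 min (a higher number here means a weaker inhibitor, a lower number a stronger inhibitor), compound 1 `Nc1nc(-c2ccccc2)nc2sc(-c3ccccc3)nc12` gives only a limit, > 30000 nM. Compound 2 `Nc1nc(-c2cccc(CO)c2)nc2sc(-c3ccccc3)nc12` likewise stops at a limit, > 30000 nM. Compound 3 `COc1ccc(-c2nc(N)c3nc(-c4ccccc4)sc3n2)cc1` also reaches only a limit, > 30000 nM. The steps among these three, a step that the two limits leave unreadable from compound 1 to compound 2, a step that the two limits leave unreadable from compound 1 to compound 3 and a step that the two limits leave unreadable from compound 2 to compound 3, cannot be sized because of the limit of > 30000 nM in this assay, at which 3 of the 3 values shown sit. Compound 4 `Cc1ccc(-c2nc(N)c3nc(-c4ccccc4)sc3n2)o1` differs from compound 1 by 5-methylfuran-2-yl in place of phenyl on an aromatic carbon. Within the data shown here, no measured step touches this change, and none of the measured steps has a readable size, so there is no ground for expecting a step in this assay beyond the scatter in either direction. Compound 4 is therefore expected to sit near the same limit. The expected step is an at least 1.2-fold lower number from compound 1 to compound 4 (0.07 log units; that floor lies within the scatter). The estimate for compound 4 is 25000 nM, ranging from 4000 nM to 150000 nM.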

Compound 4, half-maximal inhibitory concentration: > 30000 nM
Compound 4 ended at the assay's limit; the forecaster's own chance of this, stated with the estimate: 65%; middle value at least 1.2-fold (0.07 log units) from the limit.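

The steps from compound 1, compound 2 and compound 3 to compound 4 cannot be read because all four compounds stop at a limit: the limit of > 30000 nM in this assay, at which 4 of the 4 values shown sit. The compounds shown leave open what change to the shared core, if any, would give a readable value in this assay.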